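The compounds below may be only part of what the source reports. "The series", "measured", "known", "first", "only" and "open" are said of these compounds alone.

Three compounds have been measured in an ADME assay on microsomes from liver (Homo sapiens) for metabolic stability, read by HPLC, using NADPH, with a stated time of 60 min, tested at 1 uM, in the presence of a further agent that is not named here; a higher number here means that the compound lasts longer, a lower number that the compound disappears faster:

Compound 1, `Cc1cc(-c2ncccn2)cc(C(=O)NNS(=O)(=O)c2ccccc2)c1F`: 2.72 h
Compound 2, `Cc1cc(C(=O)NNS(=O)(=O)c2ccccc2F)cc(-n2cc(F)cn2)c1`: 0.2 h
Compound 3, `O=C(NNS(=O)(=O)c1ccccc1F)c1cc(F)cc(-c2ccccn2)c1`: 0.933 h

All three share a hydrazide core joined to a sulfonyl-bearing benzene ring, and they differ in the substituents on the other aromatic ring. Among the three numbers, compound 2 stands lowest, meaning it disappears fastest. The nearest value belongs to compound 3, and even that gap is beyond the usual scatter of repeated measurements; compound 1 lies further still, the widest gap of the set. So compound 2 is clearly the least stable of the three in this assay.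

Compound 4, `Cc1cc(OC(C)C)cc(C(=O)NNS(=O)(=O)c2ccccc2F)c1`, is the next compound to be tested. It differs from compound 2 in a single place: isopropoxy in place of 4-fluoro-1H-pyrazol-1-yl on an aromatic carbon. Within the data shown here, no pair of measured compounds differing in only one place is available, so there is no measured step to lean on for this change. With compound 2 already at the short end, and with nothing in the data to say whether an isopropoxy group lengthens or shortens the half-life, the expected step in this assay is a 1.3-fold higher number from compound 2 to compound 4 (0.10 log units; within the scatter), lying within the usual scatter. Compound 4 is therefore estimated to give about 0.25 h, with a likely range from 0.1 h to 0.7 h.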

Compound 4, half-life: 0.5 h
Estimate against measurement, compound 4: 2.0-fold (0.30 log units) below; measured number inside the range.
By their numbers in this assay, from the lowest: compound 2; then compounds 4 and 3 (each within the scatter of the next); then compound 1.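

Replacing 4-fluoro-1H-pyrazol-1-yl with isopropoxy gives, in this assay, a 2.5-fold higher number from compound 2 to compound 4 (0.40 log units; beyond the scatter) and so a compound that lasts longer. Among these compounds, this is the first measured change in a single place, as the earlier compounds all differ in more than one, and it shows that the group on this aromatic carbon, meta to a methyl group, can shift the half-life beyond the usual scatter, even though the step is modest and a group with no ring is exchanged for a five-membered aromatic ring. Nothing measured here explains the change, so it stands as an observation on this one pair.

The compounds shown leave open whether the longer half-life comes from having isopropoxy at this carbon or simply from no longer having 4-fluoro-1H-pyrazol-1-yl there, and whether the same change would hold with other groups elsewhere on the molecule. A shorter ether such as methoxy, a longer chain such as butoxy, or an amine on the same carbon would help to tell these possibilities apart.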